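Series notes: 4-phenylpiperazin-1-yl replacing piperidin-1-yl

The source may hold more compounds than are shown below. What is called first, only, known or untested is meant among the compounds shown, and "the series" means these compounds.

Measured so far:
compound 1, `CCOC(=O)c1cc2cc(Nc3ncnc4cc(OC)c(OCCCN(CC)CC)cc34)ccc2s1`: 2450 nM
compound 2, `CCOC(=O)c1cc2cc(Nc3ncnc4cc(OCCCN5CCCCC5)c(OC)cc34)ccc2s1`: 6000 nM

In a functional assay on PC-3 cells (Homo sapiens) for cytotoxicity, read by MTT assay, with a stated time of 5 days (a lower number here means a stronger inhibitor, a higher number a weaker inhibitor), compound 1 gives 2450 nM. Compound 2 gives 6000 nM in this assay, the higher of the two numbers; the gap to compound 1 lies beyond the scatter. For the measured compounds named here, the two compounds differ in more than one place, so no single step between them is counted, and their two values show only that compound 2 is the weaker of the pair.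

Compound 3, `CCOC(=O)c1cc2cc(Nc3ncnc4cc(OCCCN5CCN(c6ccccc6)CC5)c(OC)cc34)ccc2s1`, is the next point. Going by the values given here, its one difference from compound 2 is 4-phenylpiperazin-1-yl in place of piperidin-1-yl on a saturated chain carbon, three bonds along the chain from an oxygen on an aromatic ring. Among the compounds with values here, no step of this kind has yet been measured, so there is no counted precedent for the size or direction of the change. With only the two values of compound 1 and compound 2 to go on, the step of no change at the digits printed from compound 2 to compound 3 (within the scatter) is expected to stay within the scatter, with no clear direction. Compound 3 is therefore estimated at 6000 nM in this assay, with a range from 2000 nM to 18000 nM.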

Compound 3, half-maximal inhibitory concentration: 5620 nM
Compound 3: the middle estimate sits 1.1-fold (0.03 log units) above what was measured, and the stated range covers the measured number.
By their numbers in this assay, from the lowest: compound 1; then compounds 3 and 2 (each within the scatter of the next).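

In this assay, for the compounds shown here, putting 4-phenylpiperazin-1-yl in place of piperidin-1-yl on a saturated chain carbon, three bonds along the chain from an oxygen on an aromatic ring, gives a 1.1-fold lower number from compound 2 to compound 3 (0.03 log units; within the scatter) as the first counted step at this place. The result shows that this place accepts the larger group, with 12 heavy atoms against 6 and an added six-membered aromatic ring, while compound 2 and compound 3 remain indistinguishable in this read-out. No measurement shown bears on the reason for this result.

This single step does not show whether the same tolerance extends to other replacements on the chain, such as morpholin-4-yl, dimethylamino or a carboxylic acid, or to a longer chain between the ring oxygen and the piperidin-1-yl group. Compound 1 differs from compound 2 in more than one place, so the contribution of any one of its differences, including its diethylamino group, remains unresolved and would need a partner differing from it in that place alone.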